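Amide branching in a cytotoxicity series at the limit

The source may report more compounds than this note shows. Statements on the series, on what has been measured and on what is new or still open speak of the compounds shown alone.

Measured compounds:
- compound 1 `C=CC1=C(C(=O)NCc2ccc(C)cc2)C(c2ccc(F)cc2)OC1`: in a functional assay on A549 cells (Homo sapiens) for cytotoxicity, read by MTT assay, with a stated time of 24 h (a lower number here means a stronger inhibitor, a higher number a weaker inhibitor), compound 1 gives > 100000 nM, a limit of the assay.
- compound 2 `C=CC1=C(C(=O)O)C(c2ccc(F)cc2)OC1`: in this assay compound 2 gives > 100000 nM, a limit.
- compound 3 `C=CC1=C(C(=O)NCC(C)C)C(c2ccc(F)cc2)OC1`: in this assay compound 3 gives > 100000 nM, a limit.

Compound 3 stands only at a limit in this assay, and the two other values shown are limits as well, so no ordering among compounds 1, 2 and 3 can be read. The step considered now goes from compound 3 to compound 4 `C=CC1=C(C(=O)NC(C)(C)C)C(c2ccc(F)cc2)OC1`, not yet measured: tert-butyl in place of isobutyl on an amide-type nitrogen, both groups having the same atoms joined differently.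

Two measured steps reach compound 3. The step that the two limits leave unreadable from compound 1 to compound 3 and the step that the two limits leave unreadable from compound 2 to compound 3 are both unreadable, since each joins two limits; this rests on (the limit of > 100000 nM in this assay, at which 3 of the 3 values shown sit). Nothing measured therefore gives a direction or a size for a change on the amide nitrogen in this series.

Given that every value in this assay sits at the limit, compound 4 is expected to sit there as well, with the step that the limit leaves unreadable from compound 3 to compound 4 expected to stay within the scatter. For compound 4 the estimate in this assay is 150000 nM, with a range from 50000 nM to 500000 nM, most likely again reported only as a limit.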

Compound 4, half-maximal inhibitory concentration: > 100000 nM
Compound 4: a limit, no number; the forecaster's own chance of this, stated with the estimate: 90%; the middle value does not contradict the limit.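

In this assay compound 4 gives > 100000 nM, a limit and not a number. No step from compound 1, compound 2 or compound 3 to compound 4 can be read, since all four sit at the same limit: the limit of > 100000 nM in this assay, at which 4 of the 4 values shown sit.

The compounds shown leave open whether any change on the amide nitrogen alters cytotoxicity, in direction or in size.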